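This account rests on a few compounds, and the source may have more. Where it says the series, first, only, none or still open, it means among the compounds named here.

Measured compounds:
Compound 1 `O=C(CN1CCN(c2ccccc2F)CC1)Nc1ccc(C(=O)/C=C/c2cn(Cc3ccc(Br)cc3)nn2)cc1`: 12800 nM
Compound 2 `COc1ccccc1N1CCN(CC(=O)Nc2ccc(C(=O)/C=C/c3cn(Cc4ccc(Br)cc4)nn3)cc2)CC1`: 28000 nM

In a functional assay on SK-N-SH cells (Homo sapiens) for inhibition, read by MTT assay (a higher number here means a weaker inhibitor, a lower number a stronger inhibitor), compound 1 gives 12800 nM, and compound 2 gives 28000 nM. Going by the values given here, of the two numbers in hand, compound 2 has the higher one: the single measured step, a 2.2-fold higher number from compound 1 to compound 2 (0.34 log units; beyond the scatter), shows compound 2 to be the weaker inhibitor of the pair, by a margin that is modest but real.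

Compound 3 `CC(C)(C)OC(=O)N1CCN(CC(=O)Nc2ccc(C(=O)/C=C/c3cn(Cc4ccc(Br)cc4)nn3)cc2)CC1` has not been measured. It differs from compound 2 in one place: tert-butoxycarbonyl in place of 2-methoxyphenyl on an amine nitrogen in a ring. Among the compounds with values here, this is a larger alteration than the one measured step, which swapped one small group for another on an aromatic carbon. That step, a 2.2-fold higher number from compound 1 to compound 2 (0.34 log units; beyond the scatter), was modest, and it does not reveal how the shared core behaves once the whole 2-methoxyphenyl group gives way to a tert-butoxycarbonyl group. Without a direct precedent, the expectation for compound 3 is a number close to that of compound 2, with generous room on both sides. Compound 3 is therefore estimated at 25000 nM in this assay, within a range from 8000 nM to 80000 nM. That estimate means a step of a 1.1-fold lower number from compound 2 to compound 3 (0.05 log units; within the scatter), expected to stay within the scatter.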

Compound 3, half-maximal inhibitory concentration: 25800 nM
Beside the measured number, compound 3's estimate is 1.0-fold (0.01 log units) below it; the measured number falls inside the stated range.
By their numbers in this assay, from the lowest: compounds 1, 3 and 2 (each within the scatter of the next, the first and the last beyond it).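

In this assay, the amine nitrogen in the ring keeps its activity when the aromatic ring on it is lost altogether: tert-butoxycarbonyl in place of 2-methoxyphenyl gives a 1.1-fold lower number from compound 2 to compound 3 (0.04 log units; within the scatter). The same group in place of 2-fluorophenyl gives a 2.0-fold higher number from compound 1 to compound 3 (0.30 log units; within the scatter), so compound 3 lies within the scatter of both compounds that carry an aromatic ring here, even though those two lie beyond the scatter of each other. The earlier pair showed only that a small swap on the aromatic ring can shift the number modestly, whereas this result shows that, among these three compounds, an aromatic ring on this nitrogen is not needed for activity at this level.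

The compounds shown leave open what a plain hydrogen, a methyl group or an acetyl group on this nitrogen would give, and whether any group here can move the number well beyond the scatter. Nothing available accounts for why such different groups read alike in this series.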